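Lengthening the Chain Between Sulfur and Chloromethyl Ketone

The source may report more compounds than this note shows. Statements on the series, on what has been measured and on what is new or still open speak of the compounds shown alone.

For the measured compounds named here, compound 1 `CC(C)=CCC/C(C)=C/CC/C(C)=C/CSC[C@H](NC(=O)OC(C)(C)C)C(=O)CCl` is the only member of this small set with a full number. In a functional assay on MOLT-3 cells (Homo sapiens) (a higher number here means a weaker inhibitor, a lower number a stronger inhibitor), compound 1 gives 7700 nM. Compound 2 `CC(C)=CCC/C(C)=C/CC/C(C)=C/CSCC(=O)CCl` shares the long unsaturated chain and the sulfur of compound 1. In this assay compound 2 reaches only a limit of the assay, > 100000 nM, so its true value is not known beyond (the limit of > 100000 nM in this assay, at which 1 of the 2 values shown sits). Compound 3 `CC(C)=CCC/C(C)=C/CC/C(C)=C/CSCCC(=O)CCl` differs from compound 2 in a single place: ((chloromethyl)carbonyl)methyl in place of (chloromethyl)carbonyl on a saturated chain carbon bound to a sulfur. Going by the values given here, no measured pair shows this step, and compound 2 itself offers nothing but a limit, so the step from compound 2 to compound 3 is expected to be an at least 1.2-fold lower number from compound 2 to compound 3 (0.09 log units; that floor lies within the scatter), which is to say nothing clearly beyond the scatter. Compound 3 is therefore expected to give about 80000 nM in this assay, likely between 20000 nM and 300000 nM, with a real chance that this assay again returns only a limit.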

Compound 3, half-maximal inhibitory concentration: 35500 nM
For compound 3 the middle estimate is 2.3-fold (0.35 log units) above the measured one, within the range that was stated.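

In this assay, the longer ((chloromethyl)carbonyl)methyl group on the saturated chain carbon bound to a sulfur gives an at least 2.8-fold lower number from compound 2 to compound 3 (0.44 log units; beyond the scatter), so lengthening the chain at this position does lower the number. The true size of this step stays unknown because compound 2 provides only a limit: the limit of > 100000 nM in this assay, at which 1 of the 3 values shown sits.

Hydrogen in place of (tert-butoxycarbonyl)amino gives a 4.6-fold higher number from compound 1 to compound 3 (0.66 log units; beyond the scatter), so the lengthened chain without that group does not match compound 1, and the (tert-butoxycarbonyl)amino group clearly matters to the number in this pair.

On these data alone, whether a still longer chain, such as 2-((chloromethyl)carbonyl)ethyl on the sulfur, would lower the number further remains open. As far as these compounds go, it is also open whether a free amine in that place would keep the number of compound 1 or lose it as hydrogen does.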